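This account rests on a few compounds, and the source may have more. Where it says the series, first, only, none or still open, it means among the compounds named here.

In a functional assay on PC-3 cells (Homo sapiens) for inhibition, read by sulforhodamine B assay, with a stated time of 48 h (a higher number here means that more compound is tolerated, a lower number that less compound is tolerated), three compounds have been measured so far. Compound 1 `COc1cc(-c2cc(/C=C/C(=O)c3ccc(N)cc3)[nH]n2)cc(OC)c1OC` reaches only a limit in this assay, > 100000 nM. Compound 3 `COc1ccc(-c2cc(/C=C/C(=O)c3ccc(N)cc3)[nH]n2)cc1OC` likewise reaches only a limit, > 100000 nM. Among the compounds with values here, compound 2 `COc1ccc(C(=O)/C=C/c2cc(-c3cc(OC)c(OC)c(OC)c3)n[nH]2)cc1OC` gives the sole number, 5760 nM. The change from compound 3 to compound 1 is methoxy in place of hydrogen on an aromatic carbon; the step that the two limits leave unreadable from compound 3 to compound 1 cannot be sized, as both values sit at the limit of > 100000 nM in this assay, at which 2 of the 3 values shown sit. The step of an at least 17-fold lower number from compound 1 to compound 2 (1.23 log units; beyond the scatter) is large and beyond the scatter. How the core of compound 2 differs from that of compound 3 is not broken down here.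

Compound 4 `COc1cc(C(=O)/C=C/c2cc(-c3cc(OC)c(OC)c(OC)c3)n[nH]2)cc(OC)c1OC` is not yet measured. It differs from compound 2 by methoxy in place of hydrogen on an aromatic carbon, the same change as that from compound 3 to compound 1. That earlier step is unreadable, so the expectation for compound 4 rests on the value of compound 2 5760 nM alone, with no measured guidance on the direction or size of the change. The step expected in this assay is a 1.2-fold lower number from compound 2 to compound 4 (0.06 log units; within the scatter). Compound 4 is expected to give about 5000 nM in this assay, with a plausible range from 1500 nM to 25000 nM.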

Compound 4, concentration lethal to 50% of the cells: 7360 nM
Estimate against measurement, compound 4: 1.5-fold (0.17 log units) below; low and high end bracket the measured number.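

In this assay, methoxy in place of hydrogen on an aromatic carbon gives a 1.3-fold higher number from compound 2 to compound 4 (0.11 log units; within the scatter), so on this core the two compounds cannot be told apart. The same change on the other core, from compound 3 to compound 1, cannot be read, because both of those values are limits of the assay and not numbers: the limit of > 100000 nM in this assay, at which 2 of the 4 values shown sit. The series therefore offers one readable instance of this change, which shows that it stays within the scatter on the core of compound 2, but it does not show whether that result carries over to the core of compound 3.

The aromatic ring on the carbonyl carbon bears only methoxy or amino groups in the compounds shown, so it remains open how a hydroxy group or a fluorine atom on that ring would read. Going by these compounds, it also remains open whether the change would give a readable number on a core that carries the 4-aminophenyl group.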